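Pyrazole in Place of Fluoropyridine on a Sulfonamide Scaffold

The source may hold more compounds than are shown below. What is called first, only, known or untested is meant among the compounds shown, and "the series" means these compounds.

Compound 2 `O=S(=O)(Nc1ncccn1)c1ccc2c(c1)OCC[C@@H]2c1ccc(C(F)(F)F)cc1-c1ccc(F)nc1` was examined in an ADME assay on a cell-free system (plasma, Mus musculus) for protein binding, and gave 95.4%. Among the two values measured, compound 2 stands at the lowest unbound fraction; its nearest neighbour is compound 1 `Cn1nccc1-c1cc(C(F)(F)F)ccc1[C@H]1CCc2cc(S(=O)(=O)Nc3ncccn3)ccc21`, which in this assay gives 92.9%, a difference that lies within the scatter of the method. Compound 3 `Cn1nccc1-c1cc(C(F)(F)F)ccc1[C@H]1CCOc2cc(S(=O)(=O)Nc3ncccn3)ccc21` has not yet been measured in this assay. It differs from compound 2 in one place: 1-methyl-1H-pyrazol-5-yl in place of 6-fluoropyridin-3-yl on an aromatic carbon. Compound 1 already carries the same 1-methyl-1H-pyrazol-5-yl group on a different core, and its value sits close to that of compound 2, so there is no basis here for a large shift in either direction. He therefore expects the step a 1.4-fold higher unbound fraction from compound 2 to compound 3 (0.15 log units; within the scatter) to remain within the scatter, with at most a slight movement toward a higher unbound fraction. For compound 3 in this assay the estimate is 93.5%, with a range from 88% to 97%.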

Compound 3, plasma protein binding in the Mus musculus assay: 88.5%
Beside the measured number, compound 3's estimate is 1.8-fold (0.25 log units) (unbound fraction) below it, within the range that was stated.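

In the Mus musculus assay, replacing 6-fluoropyridin-3-yl with 1-methyl-1H-pyrazol-5-yl on this aromatic carbon, ortho to a large group and meta to a trifluoromethyl group, gives a 2.5-fold higher unbound fraction from compound 2 to compound 3 (0.40 log units; beyond the scatter). For the compounds shown here, this is the first one-place step available here, and it shows that the group at this position can move the unbound fraction beyond the scatter, which the earlier compounds, differing in more than one place, could not show. In a physicochemical assay for solubility (on this read-out higher numbers stand for higher solubility and lower numbers for lower solubility), compound 2 gives 408000 nM and compound 3 gives 532000 nM, which amounts to a 1.3-fold higher number from compound 2 to compound 3 (0.12 log units; within the scatter), so the pair stands apart on plasma protein binding but not on solubility.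

No measured finding at hand accounts for the step in the unbound fraction. As far as these compounds go, it remains open whether an amine, a carboxylic acid or a longer chain on this aromatic carbon would shift the unbound fraction in the Mus musculus assay further, and whether the same exchange of groups would give a step of similar size on the core of compound 1.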